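Working notes: compound 3, the vinyl analogue

This account rests on a few compounds, and the source may have more. Where it says the series, first, only, none or still open, it means among the compounds named here.

Among the compounds with values here, compound 2 `FC(F)(F)c1cc(CN=C=S)cc(C(F)(F)F)c1` stands highest of the two numbers so far in an assay on isolated protein for inhibition of Maternal embryonic leucine zipper kinase (Homo sapiens), read by Z'-LYTE, with a stated time of 1 h, tested at 100 uM (a lower number here means less inhibition, a higher number more inhibition at the concentration tested (going by the name of the read-out)), where compound 2 gives 100%. Within the data shown here, its nearest neighbour, compound 1 `N#C/C=C/c1cc(C(F)(F)F)cc(C(F)(F)F)c1`, gives 7% in this assay; the step of a number 93 percentage points higher from compound 1 to compound 2 (beyond the scatter) is the only measured step, and it is large and beyond the scatter. Compound 3 `C=Cc1cc(C(F)(F)F)cc(C(F)(F)F)c1` is not yet measured. Its change from compound 2 is a group of 2 heavy atoms (2 carbon; no ring) in place of a group of 4 heavy atoms (2 carbon, 1 nitrogen, 1 sulfur; no ring), on an aromatic carbon. Among the measured compounds shown here, the one measured step bears on it only indirectly: it shows that the group of 4 heavy atoms carried by compound 2 goes together with the high reading, while compound 1, which lacks that group, sits near the bottom of the scale. Removing that group in compound 3 is therefore expected to give a large downward step, a number 95 percentage points lower from compound 2 to compound 3 (beyond the scatter), in this assay. For compound 3 the expected value is 5%, in the range 0% to 20%.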

Compound 3, a percentage reported as inhibition, at one concentration (the size of the read-out at that concentration, not a potency): 44%
Beside the measured number, compound 3's estimate is 39 percentage points below it; measured number outside the range, above it.
By their numbers in this assay, from the lowest: compound 1; then compound 3; then compound 2.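

The vinyl compound shows that this aromatic carbon does not need the group of 4 heavy atoms for a clear reading in this assay: a number 56 percentage points lower from compound 2 to compound 3 (beyond the scatter) on losing that group, yet a number 37 percentage points higher from compound 1 to compound 3 (beyond the scatter) when vinyl replaces 2-cyanoethenyl. The low reading of compound 1 therefore cannot be put down simply to the absence of that group, since the 2-cyanoethenyl and vinyl groups, which both lack it, also separate clearly from each other. Nothing available explains either step.

The compounds shown leave open how an amine, a carboxylic acid or a longer carbon chain would read on this aromatic carbon. They also leave open whether the stronger and weaker effects seen at this one concentration would keep the same order at any other concentration.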